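Changing the sulfonyl substituent of compound 2

The compounds below may be only part of what the source reports. "The series", "measured", "known", "first", "only" and "open" are said of these compounds alone.

Compound 1 `O=C(O)COc1ccc(Cl)cc1C#Cc1ccc(CO)cc1F`: < 10 mL.min-1.g-1
Compound 2 `COCCNS(=O)(=O)c1ccc(C)c(C#Cc2cc(Cl)ccc2OCC(=O)O)c1`: < 10 mL.min-1.g-1

Both entries come from an in vitro ADME assay on microsomes from liver (Homo sapiens) for metabolic stability, read by LC-MS, tested at 1 uM (a higher number here means faster removal of the compound, a lower number slower removal), and neither is a number. Compound 1 is reported only as a limit, < 10 mL.min-1.g-1. Compound 2 is likewise reported only as a limit, < 10 mL.min-1.g-1. Compound 2 therefore stands at the limit of < 10 mL.min-1.g-1 in this assay, at which 2 of the 2 values shown sit.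

Compound 3 `Cc1ccc(S(=O)(=O)N2CCCCC2C)cc1C#Cc1cc(Cl)ccc1OCC(=O)O` differs from compound 2 in one place: 2-methylpiperidin-1-yl in place of (2-methoxyethyl)amino on a sulfonyl sulfur. On the sulfonyl sulfur, 2-methylpiperidin-1-yl takes the place of (2-methoxyethyl)amino, so a six-membered non-aromatic ring enters where the leaving group had none.

For the measured compounds named here, no measured pair shows the size of such a change in this assay, and the expected direction, upward, rests on the structural change alone. The expected step is an at least 1.4-fold higher number from compound 2 to compound 3 (0.14 log units; that floor lies within the scatter), a modest one. Compound 3 is estimated at 14 mL.min-1.g-1. The expected range runs from 6 mL.min-1.g-1 to 35 mL.min-1.g-1.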

Compound 3, intrinsic clearance in microsomes: 89 mL.min-1.g-1
Compound 3: the middle estimate sits 6.4-fold (0.80 log units) below what was measured; the measured number lies above the stated range.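

In this assay, the sulfonyl substituent turns out to matter: 2-methylpiperidin-1-yl in place of (2-methoxyethyl)amino on the sulfonyl sulfur gives an at least 8.9-fold higher number from compound 2 to compound 3 (0.94 log units; beyond the scatter). For the compounds shown here, compound 3 is the first compound here to carry a number rather than a limit, so it shows that this position can move the read-out, which compounds at the limit could not show. The true size of the step stays unknown, and the printed size is only a floor, because compound 2 is reported as a limit: the limit of < 10 mL.min-1.g-1 in this assay, at which 2 of the 3 values shown sit.

The swap brings in a ring and a methyl group and removes a hydrogen-bond donor and a hydrogen-bond acceptor all at once, and the compounds shown do not separate these changes. Going by these compounds, what a plain piperidin-1-yl or a morpholin-4-yl ring would give on the same sulfur remains open.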